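The source may hold more compounds than are shown below. What is called first, only, known or untested is meant among the compounds shown, and "the series" means these compounds.

Measured so far in an assay on LX2 cells for inhibition of COL1A1 promoter (Homo sapiens), read by a luciferase reporter, with a stated time of 24 h, tested at 20 uM; on this read-out higher numbers stand for a stronger effect at the one concentration tested and lower numbers for a weaker effect:

Compound 1, `CC[N+]1(CCCCCCCOc2ccc(-n3cc(C(=O)Nc4cc(F)cc(F)c4)c(=O)c4ccc(N(C)C)nc43)cc2C)CCCCC1`: 19.7%
Compound 2, `CC[N+]1(CCCCCCCOc2ccc(-n3cc(C(=O)Nc4cc(F)cc(F)c4)c(=O)c4ccc(N(C)C)nc43)cc2Cl)CCCCC1`: 14.3%
Compound 3, `Cc1cc(OCCCCCCC[N+](C)(C)C2CCCCC2)ccc1-n1cc(C(=O)Nc2cc(F)cc(F)c2)c(=O)c2ccc(N(C)C)nc21`: "not active" (no number reported)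

Compound 1 and compound 2 share one core and differ in a single place: chloro in place of methyl on an aromatic carbon. The step of a number 5.4 percentage points lower from compound 1 to compound 2 (within the scatter); the two values are within the scatter of each other, so no order between compound 1 and compound 2 is claimed.

Compound 3 carries a different core. How the core of compound 3 differs from the core of compound 1 is not broken down here. Compound 3 gave no number in this assay and stands as not active.

Compound 4, `CN(C)c1ccc2c(=O)c(C(=O)Nc3cc(F)cc(F)c3)cn(-c3ccc(OCCCCCCC[N+](C)(C)C4CCCCC4)cc3Cl)c2n1`, is not yet measured. It differs from compound 3 in one place: chloro in place of methyl on an aromatic carbon. The place is described in the same words as for the pair compound 1 to compound 2, so this is the same change, made for the second time among the compounds shown.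

What is known of this change comes from one measured pair, where it moved the read-out within the scatter. The core of compound 4 is that of compound 3, which gave no number. Among the compounds with values here, compound 4 is therefore expected to show a weak effect in this assay, because the only measured instance of the change, a number 5.4 percentage points lower from compound 1 to compound 2 (within the scatter), lies within the scatter and compound 3 was not active. The estimate for compound 4 is 8%, expected to fall between 0% and 20%, with a real chance that only a limit is reported again.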

Compound 4, a percentage reported as inhibition, at one concentration (the size of the read-out at that concentration, not a potency): "not active" (no number reported)
Nothing numeric was reported for compound 4, and the estimate cannot be compared.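

In this assay compound 3 gives "not active" (no number reported) and compound 4 gives "not active" (no number reported) and so no step can be read between them. The compounds shown leave open whether chloro in place of methyl on an aromatic carbon changes the read-out at all on the core shared by compound 3 and compound 4. No evidence bears on this result.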